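3-Chlorophenyl to 4-chlorophenyl swap in an anilide series

A few compounds are considered here, and "the series" means these few. Any claim that something is new, unique, unknown or untested is made for them only; others in the source may bear on it.

Four anilides carrying two thioester groups on a shared chain are compared. Compound 1 `CC(=O)SCCC(CCCCC(=O)Nc1cccc(Cl)c1)SC(C)=O` and compound 2 `CC(=O)SCCC(CCCCC(=O)Nc1ccc(Cl)cc1)SC(C)=O` share the same core; compound 3 `O=C(CCCCC(CCSC(=O)c1ccccc1)SC(=O)c1ccccc1)Nc1cccc(Cl)c1` and compound 4 `O=C(CCCCC(CCSC(=O)c1ccccc1)SC(=O)c1ccccc1)Nc1ccc(Cl)cc1` share a second core. The difference between the two cores is not broken down here.

In a functional assay on Bel-7402 cells (Homo sapiens) for inhibition, read by MTT assay, with a stated time of 24 h, tested at 0.1 ug/mL (a lower number here means less inhibition of growth, a higher number more inhibition of growth at the concentration tested), compound 1 gives 3.72%. Compound 2 gives 9.96%. The change 4-chlorophenyl in place of 3-chlorophenyl on an amide-type nitrogen makes the step of a number 6.2 percentage points higher from compound 1 to compound 2 (within the scatter). Compound 3 gives 1.7%; its values and those of compound 1 and compound 2 all lie within the scatter of one another.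

Compound 4 is not yet measured. It differs from compound 3 by 4-chlorophenyl in place of 3-chlorophenyl on an amide-type nitrogen, the same change as from compound 1 to compound 2, made at the same kind of place. Because the step of a number 6.2 percentage points higher from compound 1 to compound 2 (within the scatter) was within the scatter, a step of about a number 5.3 percentage points higher from compound 3 to compound 4 (within the scatter) is expected from compound 3 to compound 4, on the basis of this one matched pair alone. Compound 4 is estimated to give 7%, with a range from 0% to 18%.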

Compound 4, percent growth inhibition at one concentration: 9.2%
Compound 4: the middle estimate sits 2.2 percentage points below what was measured; low and high end bracket the measured number.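

In this assay, 4-chlorophenyl in place of 3-chlorophenyl on an amide-type nitrogen gives a number 7.5 percentage points higher from compound 3 to compound 4 (within the scatter), and the comparison with the earlier step reads: the same change on two cores in this assay, a number 6.2 percentage points higher (within the scatter) from compound 1 to compound 2 and a number 7.5 percentage points higher (within the scatter) from compound 3 to compound 4, 1.3 percentage points apart, within the scatter of two such steps. The change therefore carries across the two cores shown without a detectable difference in the size of the step. This does not show that the change itself affects growth inhibition, since each step on its own lies within the scatter, and two cores at one concentration give no basis for a rule covering other cores.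

Open, going by these compounds, is whether the same reading holds with an unsubstituted phenyl or a methoxyphenyl on the amide-type nitrogen, with a free thiol in place of the thioester groups, or with a longer chain. Also open, on these data alone, is whether the 3-chlorophenyl and 4-chlorophenyl compounds would separate beyond the scatter at another concentration.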